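The source may report more compounds than this note shows. Statements on the series, on what has been measured and on what is new or still open speak of the compounds shown alone.

In a functional assay on MCF cells (Homo sapiens) for antiproliferative activity, with a stated time of 72 h (on this read-out lower numbers stand for stronger inhibition and higher numbers for weaker inhibition), compound 1 `OC[C@H]1O[C@@H](n2cnc3c(NCc4ccccc4F)ncnc32)[C@H](O)[C@@H]1O` gives > 166000 nM as a limit of the assay, not a number. Compound 2 `OC[C@H]1O[C@@H](n2cnc3c(NCc4ccccc4Br)ncnc32)[C@H](O)[C@@H]1O` gives > 166000 nM and this too is only a limit, so compound 2 has no exact place on the scale. The evidence so far is the limit of > 166000 nM in this assay, at which 2 of the 2 values shown sit, and no more. Compound 3 `OC[C@H]1O[C@@H](n2cnc3c(NCc4cccc(Br)c4)ncnc32)[C@H](O)[C@@H]1O` has the same atoms as compound 2, joined differently: 3-bromophenyl in place of 2-bromophenyl on a saturated chain carbon bound to a nitrogen on an aromatic ring and so 3-bromophenyl stands in place of 2-bromophenyl on a saturated chain carbon bound to a nitrogen on an aromatic ring. For the measured compounds named here, the only measured step that bears on this is a step that the two limits leave unreadable from compound 1 to compound 2 and it offers no size to carry over. No clear step in either direction is therefore expected in this assay and another limit is the likeliest report. For compound 3 the estimated value is 170000 nM with an expected range from 90000 nM to 300000 nM as its ends. The expected change is a step that the limit leaves unreadable from compound 2 to compound 3 and no more than that.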

Compound 3, half-maximal inhibitory concentration: > 166000 nM
Compound 3: a limit, no number (the forecaster's own chance of this, stated with the estimate: 75%); the middle value does not contradict the limit.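

In this assay compound 3 gives > 166000 nM, a limit and not a number. For the compounds shown here, no step between compound 1, compound 2 and compound 3 can be read. Going by these compounds, whether 2-bromophenyl and 3-bromophenyl differ at all, and what exact value any of the three compounds has, stays open.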